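The compounds below may be only part of what the source reports. "The series", "measured", "known", "first", "only" and "open" are said of these compounds alone.

Three compounds share one core and differ only in the saturated ring attached to it. In a functional assay on HEK293 cells for activation of melanin-concentrating hormone receptor 1 (Rattus norvegicus), read by inositol phosphate accumulation (on this read-out higher numbers stand for an effect only at larger amounts of compound and lower numbers for an effect already at smaller amounts), compound 1 `NC1CCN(c2ccc3cc(NC(=O)CCc4ccc(C(F)(F)F)cc4)ccc3n2)C1` gives 200 nM. Compound 2 `O=C(CCc1ccc(C(F)(F)F)cc1)Nc1ccc2nc(N3CC4CCC3C4)ccc2c1` gives 150 nM in this assay, and compound 3 `CC1CCN(c2ccc3cc(NC(=O)CCc4ccc(C(F)(F)F)cc4)ccc3n2)C1` gives 400 nM. Compound 3 therefore stands at the highest number of the three, but its distance to compound 1 is small: there is a 2.0-fold higher number from compound 1 to compound 3 (0.30 log units; within the scatter), whereas the distance to compound 2 is larger, with a 2.7-fold higher number from compound 2 to compound 3 (0.43 log units; beyond the scatter).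

Compound 4 `O=C(CCc1ccc(C(F)(F)F)cc1)Nc1ccc2nc(N3CC4CC3CO4)ccc2c1` is the next step from compound 3. The change is a group of 7 heavy atoms (5 carbon, 1 nitrogen, 1 oxygen; 2 five-membered non-aromatic rings with 1 hetero atom each) in place of a group of 6 heavy atoms (5 carbon, 1 nitrogen; one five-membered non-aromatic ring with 1 hetero atom), on an aromatic carbon.

For the measured compounds named here, two measured steps bear on this. Going from compound 2 to compound 3 replaces a two-ring group by a single ring and gives a 2.7-fold higher number from compound 2 to compound 3 (0.43 log units; beyond the scatter); the step to compound 4 runs the other way, from a single ring back to a two-ring group, so the expected direction is a lower number. The step of a 1.3-fold lower number from compound 1 to compound 2 (0.12 log units; within the scatter) shows that a change of ring at this position can also leave the number where it was. Going by the values given here, a modest lowering is therefore expected, though the added oxygen has no measured counterpart here. Compound 4 is estimated at 200 nM, within 80 nM to 500 nM, which means an expected step of a 2.0-fold lower number from compound 3 to compound 4 (0.30 log units; within the scatter).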

Compound 4, half-maximal effective concentration: 70 nM
Beside the measured number, compound 4's estimate is 2.9-fold (0.46 log units) above it; the whole stated range lies above it.
By their numbers in this assay, from the lowest: compound 4; then compounds 2, 1 and 3 (each within the scatter of the next, the first and the last beyond it).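

In this assay, the change to the oxygen-containing two-ring group gives a 5.7-fold lower number from compound 3 to compound 4 (0.76 log units; beyond the scatter), the largest step yet seen at this position on the shared core. A second ring alone does not account for this result: compound 2 also carries a two-ring group of the same heavy-atom count, yet there is a 2.1-fold lower number from compound 2 to compound 4 (0.33 log units; beyond the scatter), so two groups of similar size are not interchangeable here. For the compounds shown here, with a 2.9-fold lower number from compound 1 to compound 4 (0.46 log units; beyond the scatter) as well, compound 4 is the first compound whose number lies beyond the scatter from those of all the others, although nothing available here explains why this group gives the lowest number.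

The compounds shown cannot separate the contribution of the oxygen from that of the two-ring framework that holds it, and a single ring containing oxygen, such as morpholine, or a pyrrolidine ring carrying a hydroxyl group would help to pull these two apart. From the compounds shown here alone, it also remains open whether this gain would carry over to the human form of the receptor, since all four numbers come from the rat receptor.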